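The compounds below may be only part of what the source reports. "The series", "measured", "known", "first", "only" and "open" are said of these compounds alone.

Measured in a functional assay on HepG2 cells (Homo sapiens) for cytotoxicity, read by MTT assay, with a stated time of 72 h; on this read-out higher numbers stand for weaker inhibition and lower numbers for stronger inhibition:

Compound 1, `O=C(Nc1ccc(-n2ncc3c(Cl)cccc32)cc1)Nc1ccc(Cl)c(C(F)(F)F)c1`: 1900 nM
Compound 2, `O=C(Nc1ccc(-n2ncc3c(Br)cccc32)cc1)Nc1ccc(Cl)c(C(F)(F)F)c1`: 2000 nM
Compound 3, `O=C(Nc1ccc(-n2ncc3c(F)cccc32)cc1)Nc1ccc(Cl)c(C(F)(F)F)c1`: 29500 nM

Compound 3 stands at the highest number of the three, so it is the weakest inhibitor among them; its nearest neighbour is compound 2 and the furthest is compound 1, and both gaps are well beyond the scatter. The two steps that lead to it are large: a 16-fold higher number from compound 1 to compound 3 (1.19 log units; beyond the scatter) and a 15-fold higher number from compound 2 to compound 3 (1.17 log units; beyond the scatter). By contrast, a 1.1-fold higher number from compound 1 to compound 2 (0.02 log units; within the scatter), so the chloro and bromo compounds cannot be told apart on this read-out.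

Compound 4, `Cc1cccc2c1cnn2-c1ccc(NC(=O)Nc2ccc(Cl)c(C(F)(F)F)c2)cc1`, differs from compound 3 in one place: methyl in place of fluoro on an aromatic carbon. Among the compounds with values here, no measured step involves methyl at this position, so nothing shows directly how it will behave. What the measured compounds do show is that fluoro stands alone at a high number while chloro and bromo sit together far lower. Because a 16-fold higher number from compound 1 to compound 3 (1.19 log units; beyond the scatter) and a 15-fold higher number from compound 2 to compound 3 (1.17 log units; beyond the scatter) are both large, replacing fluoro with a different single heavy atom is expected to move the number down substantially, though with real uncertainty about how far. Compound 4 is therefore expected to give 4000 nM in this assay, within a range from 1500 nM to 15000 nM, an expected step of a 7.4-fold lower number from compound 3 to compound 4 (0.87 log units; beyond the scatter).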

Compound 4, half-maximal inhibitory concentration: 4000 nM
For compound 4 middle estimate and measured number coincide at the digits printed, and the stated range covers the measured number.
By their numbers in this assay, from the lowest: compounds 1, 2 and 4 (each within the scatter of the next, the first and the last beyond it); then compound 3.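

Until now only halogens had been seen at this position, and compound 4 shows that a carbon group can also give a low number: in this assay, methyl in place of fluoro gives a 7.4-fold lower number from compound 3 to compound 4 (0.87 log units; beyond the scatter) and brings the compound down close to the chloro and bromo compounds. Methyl in place of bromo gives a 2.0-fold higher number from compound 2 to compound 4 (0.30 log units; within the scatter) and so cannot be told apart from bromo, while methyl in place of chloro gives a 2.1-fold higher number from compound 1 to compound 4 (0.32 log units; beyond the scatter) and is a modest step just past the scatter. Among the four groups compared, then, chloro, bromo and methyl stay fairly close together and compound 3 alone goes against that grouping, though nothing measured here explains why fluoro stands apart.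

The compounds shown leave open whether plain hydrogen, an amine, a methoxy group or a longer chain such as ethyl on this aromatic carbon would stay with chloro, bromo and methyl or rise towards fluoro. They also leave open whether the same grouping would appear in other cell types, since only one cell line is shown.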